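The source may report more compounds than this note shows. Statements on the series, on what has been measured and on what is new or still open speak of the compounds shown alone.

Compound 2 `CCOCC12CCC(c3nnc(-c4ccccc4C(F)(F)F)n3C)(CC1)CC2` and compound 1 `CC(O)CCCC12CCC(c3nnc(-c4ccccc4C(F)(F)F)n3C)(CC1)CC2` share one core and differ only in the chain on a saturated chain carbon bound to a saturated ring carbon. In a functional assay on the whole organism (strain ICR) for inhibition, with Mus musculus as the target, with a stated time of 4 h, at a dose of 10 mg/kg by the oral route (on this read-out lower numbers stand for less inhibition and higher numbers for more inhibition at the one dose given (going by the name of the read-out)), compound 1 gives 97%, while compound 2 gives 44%, the lowest of the two numbers. Within the data shown here, the one measured step, a number 53 percentage points lower from compound 1 to compound 2 (beyond the scatter), shows how much that chain matters. Compound 3 `CC(F)CCCC12CCC(c3nnc(-c4ccccc4C(F)(F)F)n3C)(CC1)CC2` carries the change (3-fluorobutyl in place of ethoxy on a saturated chain carbon bound to a saturated ring carbon), which restores a four-carbon chain much like that of compound 1. Because of a number 53 percentage points lower from compound 1 to compound 2 (beyond the scatter), a large rise is expected, about a number 36 percentage points higher from compound 2 to compound 3 (beyond the scatter). Compound 3 is estimated at 80%, between 55% and 97%.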

Compound 3, a percentage reported as inhibition, in the whole organism at one dose (the size of the read-out at that dose, not a potency): 96%
Compound 3: middle estimate off by 16 percentage points, on the low side, within the range that was stated.
By their numbers in this assay, from the lowest: compound 2; then compounds 3 and 1 (each within the scatter of the next).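

In this assay the step of a number 1 percentage points lower from compound 1 to compound 3 (within the scatter) goes with fluoro in place of hydroxy on a saturated chain carbon bound to two saturated chain carbons, so the hydroxy of compound 1 is not required for this level of inhibition. The step of a number 52 percentage points higher from compound 2 to compound 3 (beyond the scatter) shows that 3-fluorobutyl, which has no hydroxy, still stands far above ethoxy at this position. No measurement given here explains why the chain matters so much. Still open, from the compounds shown here alone, is whether plain butyl without fluoro or hydroxy would match these values. An amine or a carboxylic acid on the chain, or a longer chain, also remains untested in the compounds shown.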